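Thiophen-3-yl for Ethynyl: One Step Measured, One Expected

A few compounds are considered here, and "the series" means these few. Any claim that something is new, unique, unknown or untested is made for them only; others in the source may bear on it.

Measured compounds:
compound 1 `COc1nc(N)nc2c1c(-c1ccsc1)cn2[C@@H]1O[C@H](CO)[C@@H](O)[C@H]1O` — in a functional assay on CEM-DNR-bulk cells (Homo sapiens), read by MTT assay, with a stated time of 72 h (on this read-out higher numbers stand for weaker inhibition and lower numbers for stronger inhibition), compound 1 gives > 20000 nM
compound 2 `C#Cc1cn([C@@H]2O[C@H](CO)[C@@H](O)[C@H]2O)c2nc(N)nc(OC)c12` — in this assay compound 2 gives > 20000 nM
compound 3 `C#Cc1cn([C@@H]2O[C@H](CO)[C@@H](O)[C@H]2O)c2ncnc(SC)c12` — in this assay compound 3 gives 110 nM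

The value of compound 1 is a limit of this assay and not a number. The value of compound 2 is likewise a limit. Compound 3 alone gives a number; the two others sit at the limit of > 20000 nM in this assay, at which 2 of the 3 values shown sit.

Compound 1 and compound 2 differ in a single place, (thiophen-3-yl in place of ethynyl on an aromatic carbon). Because both sit at a limit, the step that the two limits leave unreadable from compound 2 to compound 1 cannot be read, and so it gives no size to carry over.

Compound 4 `CSc1ncnc2c1c(-c1ccsc1)cn2[C@@H]1O[C@H](CO)[C@@H](O)[C@H]1O` has not yet been measured in this assay. It stands to compound 3 as compound 1 stands to compound 2: thiophen-3-yl in place of ethynyl on an aromatic carbon. The place lines of the two changes agree word for word, so this is the same kind of change, made on a different core. The difference between the core of compound 3 and the core of compound 2 is not broken down here.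

For the measured compounds named here, with the only measured instance of the change unreadable, the expectation for compound 4 rests on compound 3 at 110 nM and on the change itself, and it is held loosely. The step from compound 3 to compound 4 is expected to be a 4.5-fold higher number from compound 3 to compound 4 (0.66 log units; beyond the scatter). Compound 4 is estimated at 500 nM, expected to lie between 60 nM and 8000 nM.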

Compound 4, half-maximal inhibitory concentration: > 20000 nM
Compound 4 gave a limit, no number (the forecaster's own chance of this, stated with the estimate: 20%); middle value at least 40-fold (1.60 log units) from the limit.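

For the compounds shown here, on the core of compound 3, thiophen-3-yl in place of ethynyl on an aromatic carbon gives an at least 180-fold higher number from compound 3 to compound 4 (2.25 log units; beyond the scatter) in this assay, and this is the only instance of the change with a readable size. Compound 4 gives > 20000 nM, which is a limit of the assay and not a number, so the step has a known lower end and no known upper end. The same change on the core of compound 2 cannot be read, since both of its compounds sit at a limit, so the series shows that both thiophen-3-yl compounds end at that limit but cannot show whether the step keeps its size from one core to the other: the limit of > 20000 nM in this assay, at which 3 of the 4 values shown sit.

On these data alone, it remains open whether any other group on this aromatic carbon, such as a nitrile, a methyl or a longer alkyne chain, would keep a number on the core of compound 3 or would fall to the limit as thiophen-3-yl does. The compounds shown also leave open which part of the difference between the core of compound 3 and the core of compound 2 matters, as those two compounds differ in more than one place and no single step connects them.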